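The source may hold more compounds than are shown below. What is called first, only, known or untested is meant among the compounds shown, and "the series" means these compounds.

Working notes on the series. Compound 1 `COc1cccc(-c2cccc(NC(=O)CCc3ccc4c(c3)B(O)OC4)c2)c1` and compound 2 `CC(=O)c1ccc(-c2cccc(NC(=O)CCc3ccc4c(c3)B(O)OC4)c2)cc1` share one core; compound 3 `COc1cccc(-c2cccc(NC(=O)CCc3cccc4c3C(O)OC4)c2)c1` and compound 4 `CC(=O)c1ccc(-c2cccc(NC(=O)CCc3cccc4c3C(O)OC4)c2)cc1` share another, and the difference between the two cores is not broken down here. In a functional assay on HCT-116 cells (Homo sapiens) for antiproliferative activity, read by MTT assay, with a stated time of 72 h (on this read-out lower numbers stand for stronger inhibition and higher numbers for weaker inhibition), compound 1 gives 21000 nM, compound 2 gives 19000 nM and compound 3 gives 49000 nM. Compound 3 stands highest of the three measured numbers, beyond the scatter against both compound 1 and compound 2.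

The change from compound 1 to compound 2 is 4-acetylphenyl in place of 3-methoxyphenyl on an aromatic carbon; it made a 1.1-fold lower number from compound 1 to compound 2 (0.04 log units; within the scatter). The same change, (4-acetylphenyl in place of 3-methoxyphenyl on an aromatic carbon), is made from compound 3 to compound 4, on the other core, with the place described in the same words. Compound 4 is not yet measured in this assay.

Because the earlier step of a 1.1-fold lower number from compound 1 to compound 2 (0.04 log units; within the scatter) was within the scatter, the step from compound 3 to compound 4 is expected to be small as well, estimated at a 1.1-fold lower number from compound 3 to compound 4 (0.04 log units; within the scatter). The number for compound 4 in this assay is therefore expected near 45000 nM, estimated to lie between 20000 nM and 100000 nM.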

Compound 4, half-maximal inhibitory concentration: 18000 nM
Estimate against measurement, compound 4: 2.5-fold (0.40 log units) above; the measured number lies below the stated range.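

In this assay, 4-acetylphenyl in place of 3-methoxyphenyl gives a 2.7-fold lower number from compound 3 to compound 4 (0.43 log units; beyond the scatter), yet the size of this step cannot be told apart from that of the same change on the other core: the same change on two cores in this assay, a 1.1-fold lower number (0.04 log units; within the scatter) from compound 1 to compound 2 and a 2.7-fold lower number (0.43 log units; beyond the scatter) from compound 3 to compound 4, 2.5-fold (0.39 log units) apart, within the scatter of two such steps. The result is therefore compatible with the change carrying from one core to the other, but with one pair on each core it does not show that the step has a common size, nor does it show a real difference between the cores. With 4-acetylphenyl in place, exchanging the core gives a 1.1-fold lower number from compound 2 to compound 4 (0.02 log units; within the scatter), whereas with 3-methoxyphenyl compound 1 gives 21000 nM and compound 3 gives 49000 nM, so the core exchange may depend on the aryl group, though this rests on two pairs only.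

From the compounds shown here alone, it remains open whether the step would hold for aryl groups bearing an amine or a carboxylic acid. Going by these compounds, the effect of a longer chain in place of the saturated chain on the amide carbonyl also remains open.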